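The compounds below may be only part of what the source reports. "The series", "measured", "known", "first", "only" and "open" are said of these compounds alone.

Series notes. Compound 1 `O=C(O)Cc1sc(C(c2ccc(F)cc2)c2ccc(F)cc2)nc1-c1ccnc(F)c1` is the reference point. In an in vitro assay on HEK385-7 cells for displacement of a labelled ligand from prostaglandin D2 receptor 2 (Homo sapiens) (on this read-out higher numbers stand for weaker inhibition and lower numbers for stronger inhibition), compound 1 gives 0.48 nM, the lowest of the two numbers in hand. Compound 3 `O=C(O)Cc1sc(C(c2ccccc2)c2ccc(Cl)cc2)nc1-c1ccc(Cl)cc1` gives 45 nM in this assay, a gap to compound 1 that lies beyond the scatter. Compound 2 `COc1ccc(OC)c(-c2nc(C(c3ccccc3)c3ccccc3)sc2CC(=O)O)c1` returns only a limit in this assay, > 105 nM. That limit is the limit of > 105 nM in this assay, at which 1 of the 3 values shown sits, so compound 2 adds no number to compare against.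

Within the data shown here, no pair of measured compounds differs in a single place, so no measured step sets a scale for a one-point change. The next compound, compound 4 `O=C(O)Cc1sc(C(c2ccc(F)cc2)c2ccc(F)cc2)nc1-c1ccncc1`, differs from compound 1 by hydrogen in place of fluoro on an aromatic carbon; cut one bond further out, this reads 2-fluoropyridin-4-yl to pyridin-4-yl. The gap between compound 1 and compound 3 involves several changes at once and says nothing about the fluoro on its own. Removal of a single fluorine next to the ring nitrogen is expected to give a small step: the step of a 2.5-fold higher number from compound 1 to compound 4 (0.40 log units; beyond the scatter) is estimated to stay close to the scatter, if anything toward a weaker number. Compound 4 is expected to give 1.2 nM in this assay, with a range from 0.4 nM to 4 nM.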

Compound 4, half-maximal inhibitory concentration: 5.3 nM
Beside the measured number, compound 4's estimate is 4.4-fold (0.65 log units) below it, and the stated range ends below it.
By their numbers in this assay, from the lowest: compound 1; then compound 4; then compound 3. At a limit, above all of these: compound 2.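

The fluoro on the 2-fluoropyridin-4-yl group carries real weight in this assay: replacing this one atom with hydrogen, on an aromatic carbon next to the ring nitrogen and with the rest of the structure unchanged, gives an 11-fold higher number from compound 1 to compound 4 (1.04 log units; beyond the scatter). Among these compounds, no earlier pair of compounds differed in a single place, so this is the first scale for a one-point change, and at this position that scale is large, well past the usual scatter. Among the compounds shown here, the only information at hand beyond the potency numbers is a limit belonging to a different compound, and it offers no explanation for the size of this step.

From the compounds shown here alone, whether the step reflects fluoro specifically, or any group other than hydrogen on this carbon, stays open; a chloro, a methyl, a methoxy or an amine at the same place would separate these two readings. Also open, going by these compounds, is whether a step of this size would hold with changes elsewhere on the core of compound 1.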